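Weighing a dichlorophenyl variant against three cytotoxicity results

This account rests on a few compounds, and the source may have more. Where it says the series, first, only, none or still open, it means among the compounds named here.

Three compounds share one core and differ only in the aryl group on the saturated ring carbon. Compound 1 `N#CC1=C(N)N(c2ccc(S(N)(=O)=O)cc2)C2=C(CCCC2)C1c1ccccc1` gives 20% in a functional assay on Ehrlich cells (Mus musculus) for cytotoxicity, read by trypan blue exclusion, with a stated time of 2 h, tested at 50 ug/mL; on this read-out higher numbers stand for a stronger effect at the one concentration tested and lower numbers for a weaker effect. Compound 2 `N#CC1=C(N)N(c2ccc(S(N)(=O)=O)cc2)C2=C(CCCC2)C1c1ccc(O)cc1` gives 60% in this assay, and compound 3 `N#CC1=C(N)N(c2ccc(S(N)(=O)=O)cc2)C2=C(CCCC2)C1c1ccc([N+](=O)[O-])cc1` gives 10%. On these numbers compound 3 stands lowest of the three: its nearest neighbour is compound 1, within the scatter, and its furthest is compound 2, beyond it. The measured steps were a number 40 percentage points higher from compound 1 to compound 2 (beyond the scatter), a number 10 percentage points lower from compound 1 to compound 3 (within the scatter) and a number 50 percentage points lower from compound 2 to compound 3 (beyond the scatter).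

Compound 4 `N#CC1=C(N)N(c2ccc(S(N)(=O)=O)cc2)C2=C(CCCC2)C1c1ccc(Cl)cc1Cl` carries a change at the same position: 2,4-dichlorophenyl in place of 4-nitrophenyl on a saturated ring carbon. Going by the values given here, no measured step exchanges a nitro group for chlorine, so the steps that bear on it are those altering the same aryl substituent: a number 10 percentage points lower from compound 1 to compound 3 (within the scatter) stayed within the scatter, whereas a number 50 percentage points lower from compound 2 to compound 3 (beyond the scatter) was large. Only the hydroxy-bearing compound 2 reached a high number; compound 1 and compound 3 both sit low. The entering group brings no hydrogen-bond donor or acceptor, so for compound 4 the step of a number 15 percentage points higher from compound 3 to compound 4 (beyond the scatter) is expected to be small, upward if anything. Compound 4 is therefore estimated at 25%, within 5% to 55%.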

Compound 4, a percentage reported as activity, at one concentration (the size of the read-out at that concentration, not a potency): 50%
Beside the measured number, compound 4's estimate is 25 percentage points below it; the measured number falls inside the stated range.
By their numbers in this assay, from the lowest: compounds 3 and 1 (each within the scatter of the next); then compounds 4 and 2 (each within the scatter of the next).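

In this assay, going by these compounds alone, the exchange of 4-nitrophenyl for 2,4-dichlorophenyl on the saturated ring carbon proves large, with a number 40 percentage points higher from compound 3 to compound 4 (beyond the scatter), and the exchange of phenyl for the same group gives a number 30 percentage points higher from compound 1 to compound 4 (beyond the scatter), so compound 2 is no longer the only compound with a high number at this position. With a number 10 percentage points lower from compound 2 to compound 4 (within the scatter), compound 4 and compound 2 cannot be told apart, although the 2,4-dichlorophenyl group has 0 hydrogen-bond donors and 0 hydrogen-bond acceptors, so among these compounds a 4-hydroxyphenyl group is not needed to reach this level. Nothing given here accounts for why the two chlorine-bearing and hydroxy-bearing aryl groups read alike.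

On these data alone, the two chlorines enter together, so it stays open whether a 4-chlorophenyl or a 2-chlorophenyl group alone would match compound 4. As far as these compounds go, how a 4-aminophenyl or 4-carboxyphenyl group would read in this assay is also open, and with one concentration per compound the numbers give no ranking of potency.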